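Replacing a branched secondary amine with dipropylamino

This account rests on a few compounds, and the source may have more. Where it says the series, first, only, none or still open, it means among the compounds named here.

Of the compounds shown here, three sharing one core have been measured in an assay on cell membranes for displacement of a labelled ligand from corticotropin-releasing factor receptor 1 (Rattus norvegicus); on this read-out higher numbers stand for weaker inhibition and lower numbers for stronger inhibition. Compound 1 `CCCCN(CCC)c1nc(C)nc2c(-c3ccc(OC)nc3C)c(C)nn12` gives 2.4 nM, and compound 2 `CCCN(CC1CC1)c1nc(C)nc2c(-c3ccc(OC)nc3C)c(C)nn12` gives 1.6 nM. Compound 3 `CCCCC(C)Nc1nc(C)nc2c(-c3ccc(OC)nc3C)c(C)nn12` gives 5.1 nM, the highest of the three numbers; its step from compound 1 is a 2.1-fold higher number from compound 1 to compound 3 (0.33 log units; beyond the scatter), and from compound 2 it is a 3.2-fold higher number from compound 2 to compound 3 (0.50 log units; beyond the scatter).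

Compound 4 `CCCN(CCC)c1nc(C)nc2c(-c3ccc(OC)nc3C)c(C)nn12` differs from compound 3 in one place: dipropylamino in place of (1-methylpentyl)amino on an aromatic carbon. The amine thus loses its hydrogen-bond donor, as in compounds 1 and 2, which also carry a nitrogen bearing two chains. Both steps that bear on this, a 2.1-fold higher number from compound 1 to compound 3 (0.33 log units; beyond the scatter) and a 3.2-fold higher number from compound 2 to compound 3 (0.50 log units; beyond the scatter), show that moving from such a nitrogen to the (1-methylpentyl)amino group raised the number by a modest amount. Reversing that kind of change is therefore expected to lower it by a similar amount, bringing compound 4 close to compounds 1 and 2.

For compound 4 the expected value in this assay is 2.8 nM, with a range from 1.2 nM to 7 nM, an expected step of a 1.8-fold lower number from compound 3 to compound 4 (0.26 log units; within the scatter).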

Compound 4, half-maximal inhibitory concentration: 5.7 nM
For compound 4 the middle estimate is 2.0-fold (0.31 log units) below the measured one; the range from low to high includes it.
By their numbers in this assay, from the lowest: compounds 2 and 1 (each within the scatter of the next); then compounds 3 and 4 (each within the scatter of the next).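

In this assay the swap of (1-methylpentyl)amino for dipropylamino, which removes the hydrogen-bond donor, gives no readable difference (a 1.1-fold higher number from compound 3 to compound 4 (0.05 log units; within the scatter)), so a nitrogen bearing two chains does not on its own bring the lower numbers of compounds 1 and 2. The chains on that nitrogen count instead: propyl in place of cyclopropylmethyl gives a 3.6-fold higher number from compound 2 to compound 4 (0.55 log units; beyond the scatter) and propyl in place of butyl gives a 2.4-fold higher number from compound 1 to compound 4 (0.38 log units; beyond the scatter), both beyond the scatter, so small changes at the far end of one chain are visible here. Nothing shown explains these differences.

Because the two groups in the swap also differ in chain shape, the donor's own contribution remains unseparated. As far as these compounds go, whether dibutylamino or a ring amine such as piperidine would reach numbers like those of compounds 1 and 2 also stays open.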